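Cyanophenyl Urea Against an Inward-Rectifier Potassium Channel

The source may hold more compounds than are shown below. What is called first, only, known or untested is meant among the compounds shown, and "the series" means these compounds.

Measured so far:
compound 1, `COc1ccc(NC(=O)Nc2ccc(C)c(S(=O)(=O)N(C)C)c2)cc1`: 1700 nM
compound 2, `Cc1ccc(NC(=O)Nc2ccc(C(F)(F)F)cc2)cc1S(=O)(=O)N(C)C`: 1500 nM
compound 3, `COc1ccc(OC)c(NC(=O)Nc2ccc(C)c(S(=O)(=O)N(C)C)c2)c1`: > 10000 nM

Three ureas built on the shared core of compound 1 have been tested in an assay on HEK293 cells for activation of Kir3.1/Kir3.2 (Homo sapiens), read by fluorescence and thallium flux, with a stated time of 4 min; a higher number here means that more compound is needed for the effect, a lower number that less compound is needed. Within the data shown here, compound 1 gives 1700 nM, the higher of the two plain numbers, though its one neighbour is close: a 1.1-fold lower number from compound 1 to compound 2 (0.05 log units; within the scatter). Compound 3 does not yield a number at all but only a limit of the assay, > 10000 nM. Among the measured compounds shown here, that is the single instance of the limit of > 10000 nM in this assay, at which 1 of the 3 values shown sits.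

Compound 4, `Cc1ccc(NC(=O)Nc2cccc(C#N)c2)cc1S(=O)(=O)N(C)C`, has not yet been measured. Its difference from compound 1 is 3-cyanophenyl in place of 4-methoxyphenyl on an amide-type nitrogen. For the measured compounds named here, only one measured step speaks to this change, and only partly: it swaps one group for another on the same aryl ring while keeping a 4-substituted phenyl, and it stays within the scatter. Going by the values given here, the move to a 3-cyanophenyl has no measured counterpart, and compound 3, the other aryl variation, gave only a limit. The expectation for compound 4 is therefore a modest weakening at most, a 1.6-fold higher number from compound 1 to compound 4 (0.22 log units; within the scatter), with a wide range. Compound 4 is estimated at 2800 nM, between 900 nM and 10000 nM.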

Compound 4, half-maximal effective concentration: 3900 nM
For compound 4 the middle estimate is 1.4-fold (0.14 log units) below the measured one; low and high end bracket the measured number.
By their numbers in this assay, from the lowest: compounds 2 and 1 (each within the scatter of the next); then compound 4. At a limit, above all of these: compound 3.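

On the amide-type nitrogen of the shared core, the exchange of 4-methoxyphenyl for 3-cyanophenyl gives, in this assay, a 2.3-fold higher number from compound 1 to compound 4 (0.36 log units; beyond the scatter), which is a modest step but one that lies beyond the scatter. Among these compounds, the only earlier step with a plain number at this place stayed within the scatter, so this is the first measured sign that the number responds to the choice of aryl group here, and the response is small enough that compound 4 still gives a plain number. Nothing measured among these compounds offers a reason for the shift.

This step changes both the group on the ring and where it sits, and the compounds shown do not separate the nitrile from its place on the ring. How an aryl group carrying an amine or a carboxylic acid would behave at this nitrogen in this assay also stays open, as does whether any group here could bring the number clearly below those of the compounds shown.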